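A few compounds are considered here, and "the series" means these few. Any claim that something is new, unique, unknown or untested is made for them only; others in the source may bear on it.

Compound 3 `COC(CCn1cnc2c(NCc3ccc(C(=O)Nc4ccccc4N)cc3)nc(Cl)nc21)OC` stands as the lowest of the three numbers written down for a functional assay on HCT-116 cells (Homo sapiens) for antiproliferative activity, read by CCK-8 assay, with a stated time of 72 h, tested at 8 uM (on this read-out lower numbers stand for a weaker effect and higher numbers for a stronger effect at the one concentration tested), though its gaps to the other two are within the scatter: in this assay compound 3 gives 11.9%. Compound 1 `Nc1ccccc1NC(=O)/C=C/c1ccc(Cn2cnc3c(Nc4cccc(Cl)c4)nc(Cl)nc32)cc1` gives 15.8% in this assay, and compound 2 `Nc1ccccc1NC(=O)/C=C/c1ccc(Cn2cnc3c(NCc4ccccc4)nc(Cl)nc32)cc1` gives 17.4%. Going by the values given here, the only one-place step among the measured compounds is a number 1.6 percentage points higher from compound 1 to compound 2 (within the scatter), a step at the nitrogen that carries the aryl or benzyl group, not at the aromatic nitrogen of the five-membered ring.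

Compound 4 `CC(C)n1cnc2c(NCc3ccc(C(=O)Nc4ccccc4N)cc3)nc(Cl)nc21` differs from compound 3 by isopropyl in place of 3,3-dimethoxypropyl on an aromatic nitrogen. Among the compounds with values here, no measured step touches this aromatic nitrogen, so nothing speaks to the size of the change in this assay; the one step that is known, a number 1.6 percentage points higher from compound 1 to compound 2 (within the scatter), was within the scatter, and the whole series so far sits within a narrow band at the single concentration tested. Within the data shown here, with no step on record beyond the scatter, no shift beyond the scatter is expected for compound 4 in this assay. The step from compound 3 to compound 4 is therefore estimated as a number 1.1 percentage points higher from compound 3 to compound 4 (within the scatter). For compound 4 the value in this assay is estimated at 13%, with a range from 4% to 23%.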

Compound 4, a percentage reported as inhibition, at one concentration (the size of the read-out at that concentration, not a potency): 76%
The estimate for compound 4 lay 63 percentage points below the measured number; the whole stated range lies below it.
By their numbers in this assay, from the lowest: compounds 3, 1 and 2 (each within the scatter of the next); then compound 4.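

Going by these compounds alone, the aromatic nitrogen of the five-membered ring, untouched by any earlier step, is the first place to show a step beyond the scatter in this assay: a number 64.1 percentage points higher from compound 3 to compound 4 (beyond the scatter) stands against a number 1.6 percentage points higher from compound 1 to compound 2 (within the scatter) at the nitrogen that carries the aryl or benzyl group, which lies within the scatter. The narrow band of the first three compounds therefore says nothing general about the series, since the exchange of 3,3-dimethoxypropyl, with 7 heavy atoms and 2 hydrogen-bond acceptors, for isopropyl, with 3 heavy atoms and no such acceptors, separates compound 4 clearly from compound 3 at the single concentration tested. Nothing at hand links this step to a measured property of either group, and which difference between the two groups carries it stays unassigned.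

The pair cannot separate chain length, branching and the loss of the two oxygen atoms, a question that a straight propyl chain, a cyclopentyl ring or a 2-methoxyethyl chain on the same nitrogen would address. Also open, going by these compounds, is how a terminal amine or carboxylic acid on that chain would read, and whether isopropyl there would have a similar effect on the remainder of compound 2.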